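The source may hold more compounds than are shown below. What is called first, only, known or untested is meant among the compounds shown, and "the series" means these compounds.

Measured compounds:
Compound 1, `COc1ccc(C(=O)NCc2ccc(CNS(=O)(=O)c3ccc(C)cc3)cc2)cc1` — in an assay on MDA-MB-231 cells for binding affinity to C-X-C chemokine receptor type 4 (Homo sapiens), read by immunofluorescence and microscopy, with stated times of 10 min and 30 min (on this read-out lower numbers stand for an effect already at smaller amounts and higher numbers for an effect only at larger amounts of compound), compound 1 gives 100 nM.
Compound 2, `COc1ccccc1C(=O)NCc1ccc(CNS(=O)(=O)c2ccc(C)cc2)cc1` — in this assay compound 2 gives 100 nM.
Compound 3, `O=C(NCc1ccc(CNS(=O)(=O)c2ccccc2)cc1)c1c(Cl)cc(Cl)cc1Cl` — in this assay compound 3 gives 10 nM.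

Compound 3 stands at the lowest number of the three, and its steps to compound 1 and to compound 2 are both beyond the scatter, so it is the most potent of the measured set. Between the other two, the single measured step, no change at the digits printed from compound 1 to compound 2 (within the scatter), shows that moving the methoxy group on the benzoyl ring of the shared core leaves the read-out where it was.

Compound 4, `Cc1ccc(S(=O)(=O)NCc2ccc(CNC(=O)c3c(Cl)cc(Cl)cc3Cl)cc2)cc1`, is drawn from compound 3 by the change (methyl in place of hydrogen on an aromatic carbon). Among the measured compounds shown here, no measured step isolates this change: compounds 1 and 2 carry the (4-methylphenyl)sulfonyl group, but they also differ from compound 3 in the benzoyl part, so their values cannot be read as a test of the methyl alone. For the measured compounds named here, the only measured step, from compound 1 to compound 2, concerns a different part of the molecule and bears on it only indirectly, as an example of a small peripheral change that did nothing beyond the scatter. On that basis the step from compound 3 to compound 4 is expected to be no change at the digits printed from compound 3 to compound 4 (within the scatter) in this assay, with no movement beyond the scatter in either direction. Compound 4 is therefore estimated at 10 nM, with a range from 4 nM to 25 nM.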

Compound 4, effective concentration (reported as EC, without a stated level of effect): 10 nM
The estimate for compound 4 equals the measured number at the digits printed; the range from low to high includes it.
By their numbers in this assay, from the lowest: compounds 3 and 4 (each within the scatter of the next); then compounds 1 and 2 (each within the scatter of the next).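

In this assay the methyl on an aromatic carbon para to a large group, which turns phenylsulfonyl into (4-methylphenyl)sulfonyl, gives no change at the digits printed from compound 3 to compound 4 (within the scatter) and so this position takes the added methyl without a shift beyond the scatter. This also separates the two places in which compound 3 differed from compounds 1 and 2: with the (4-methylphenyl)sulfonyl group now held constant, 2,4,6-trichlorophenyl in place of 2-methoxyphenyl on a carbonyl carbon gives a 10-fold lower number from compound 2 to compound 4 (1.00 log units; beyond the scatter) and 2,4,6-trichlorophenyl in place of 4-methoxyphenyl on a carbonyl carbon gives a 10-fold lower number from compound 1 to compound 4 (1.00 log units; beyond the scatter) so the gap in the read-out goes with the group on the carbonyl carbon and not with the methyl. Nothing given here explains either of these results.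

The compounds shown leave open whether this position would stay as tolerant with an amine, a carboxylic acid or a longer chain such as butyl in place of the methyl. They also leave open whether all three chlorines are needed, since a phenyl carrying a single chlorine does not appear among them.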